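The compounds below may be only part of what the source reports. "The series", "measured", "known", "first", "only" and "open" are said of these compounds alone.

Working notes on the series around the shared core of compound 1 `C=CC(=O)Nc1cccc(NC(=O)CSc2nc(Nc3ccccc3)c3ccccc3n2)c1`. In a functional assay on MDA-MB-231 cells (Homo sapiens) for inhibition, read by MTT assay, with a stated time of 72 h (on this read-out lower numbers stand for stronger inhibition and higher numbers for weaker inhibition), compound 1 gives 10200 nM. Compound 2 `O=C(CSc1nc(Nc2ccccc2)c2ccccc2n1)Nc1ccc(F)cc1` gives 34100 nM in this assay, and compound 3 `O=C(CSc1nc(Nc2ccccc2)c2ccccc2n1)Nc1ccc(Br)cc1` gives 11500 nM. Compound 1 carries the lowest of the three numbers; compound 3 sits within the scatter of it, while compound 2 lies beyond it. All measured steps concern the aryl group on the amide-type nitrogen: a 3.3-fold higher number from compound 1 to compound 2 (0.52 log units; beyond the scatter); a 1.1-fold higher number from compound 1 to compound 3 (0.05 log units; within the scatter); a 3.0-fold lower number from compound 2 to compound 3 (0.47 log units; beyond the scatter). The anilino side of the core is unchanged across compounds 1, 2 and 3.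

Compound 4 `C=CC(=O)Nc1cccc(NC(=O)CSc2nc(Nc3cccc([N+](=O)[O-])c3)c3ccccc3n2)c1` differs from compound 1 on that untouched side: nitro in place of hydrogen on an aromatic carbon, on the ring of the anilino group, meta to a large group. Going by the values given here, no measured step bears on this position, so the steps above serve only to show the modest range the series covers so far; they give no direct precedent for the new group. With nothing to point either way, the expectation is a step near zero and not beyond the scatter, written as a 1.0-fold lower number from compound 1 to compound 4 (0.01 log units; within the scatter), with the range kept wide for want of precedent. Compound 4 is therefore estimated at 10000 nM in this assay, between 3500 nM and 30000 nM.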

Compound 4, half-maximal inhibitory concentration: > 50000 nM
Compound 4 gave a limit, no number (the forecaster's own chance of this, stated with the estimate: 5%); middle value at least 5.0-fold (0.69 log units) away from the limit.
By their numbers in this assay, from the lowest: compounds 1 and 3 (each within the scatter of the next); then compound 2. At a limit, above all of these: compound 4.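

In this assay, the anilino side of the shared core, unchanged across compounds 1, 2 and 3, proves able to move the read-out: nitro in place of hydrogen, on an aromatic carbon meta to a large group, gives an at least 4.9-fold higher number from compound 1 to compound 4 (0.69 log units; beyond the scatter) on the side of weaker inhibition. Going by these compounds alone, this is the only reading on this ring, as every earlier step concerned the aryl group on the amide-type nitrogen, so the series now shows that the number responds to a change at either end of the core of compound 1. The reading for compound 4 is a limit and not a number: the limit of > 50000 nM in this assay, at which 1 of the 4 values shown sits.

A single group at a single place cannot separate the effect of nitro itself from that of any addition to this ring, so an amine, a methoxy group or a chloro group at the same place would be needed to tell these apart, as would nitro elsewhere on the ring. As far as these compounds go, it also remains open whether the 3-nitrophenyl change carries the same penalty when the amide-type nitrogen bears 4-bromophenyl or 4-fluorophenyl in place of the aryl group of compound 1.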